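The source may report more compounds than this note shows. Statements on the series, on what has been measured and on what is new or still open speak of the compounds shown alone.

Compound 1 `CC(C)N(Cc1cccc(OCCCCCC(=O)O)c1)C(=O)c1ccc(-c2ccncc2)cc1` and compound 2 `CC(C)N(Cc1cccc(OCCCCCC(=O)O)c1)C(=O)c1ccc(-c2cccc(-c3ccccc3)c2)cc1` share one core and differ by 3-phenylphenyl in place of pyridin-4-yl on an aromatic carbon. In an ADME assay on HEK293 cells (Homo sapiens) for cytotoxicity, read by CellTiter-Glo and resazurin assay, with a stated time of 72 h (a higher number here means that more compound is needed for the effect, a lower number that less compound is needed), compound 1 gives only a limit, > 26000 nM. In this assay compound 2 gives only a limit as well, > 26000 nM. Between the two stands a step that the two limits leave unreadable from compound 1 to compound 2, because of the limit of > 26000 nM in this assay, at which 3 of the 3 values shown sit. Compound 3 `CCOC(=O)CCCCCOc1cccc(CN(C(=O)c2ccc(-c3ccncc3)cc2)C(C)C)c1` is compound 1 with ethyl in place of hydrogen on an oxygen next to a carbonyl group, and that is the whole difference between the two cores. In this assay compound 3 also gives only a limit, > 26000 nM. Compound 4 `CCOC(=O)CCCCCOc1cccc(CN(C(=O)c2ccc(-c3cccc(-c4ccccc4)c3)cc2)C(C)C)c1` arises from compound 3 by 3-phenylphenyl in place of pyridin-4-yl on an aromatic carbon, the same change at the same place as that from compound 1 to compound 2. Because the limit of > 26000 nM in this assay, at which 3 of the 3 values shown sit, holds every value seen so far, compound 4 is expected to stay at that limit, with an estimated step that the limit leaves unreadable from compound 3 to compound 4. Compound 4 is therefore estimated at 30000 nM, between 15000 nM and 80000 nM.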

Compound 4, half-maximal effective concentration: > 26000 nM
Compound 4 ended at the assay's limit; the forecaster's own chance of this, stated with the estimate: 85%; the middle value is on the limit's open side.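

No step can be read from compound 3 to compound 4 or from compound 2 to compound 4, since these values are all limits: the limit of > 26000 nM in this assay, at which 4 of the 4 values shown sit. The compounds shown leave open what concentration any of them needs in this assay and whether either change shifts it.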